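The source may hold more compounds than are shown below. What is called first, only, known or untested is meant among the compounds shown, and "the series" means these compounds.

Compound 3 `COc1ccc(-c2nnc(COc3cnn(C(C)(C)C)c(=O)c3Cl)o2)cc1` gives 17.7 ug/mL in a functional assay on the whole organism for inhibition, with Mythimna separata as the target, with a stated time of 5 days (on this read-out higher numbers stand for an effect only at larger amounts of compound and lower numbers for an effect already at smaller amounts), the lower of the two numbers shown, although a 1.2-fold lower number from compound 1 to compound 3 (0.08 log units; within the scatter) is within the scatter. Compound 1 `CC(C)(C)n1ncc(OCc2nnc(-c3ccc(Br)cc3)o2)c(Cl)c1=O` gives 21.4 ug/mL. Compound 2 `Cc1nnc(COc2cnn(C(C)(C)C)c(=O)c2Cl)o1` gives > 300 ug/mL, a limit of the assay. Compound 4 `Cc1cccc(-c2nnc(COc3cnn(C(C)(C)C)c(=O)c3Cl)o2)c1` differs from compound 3 by 3-methylphenyl in place of 4-methoxyphenyl on an aromatic carbon. The measured steps bearing on this are an at least 14-fold higher number from compound 1 to compound 2 (1.14 log units; beyond the scatter) and an at least 16-fold lower number from compound 2 to compound 3 (1.22 log units; beyond the scatter), both large, against a 1.2-fold lower number from compound 1 to compound 3 (0.08 log units; within the scatter), within the scatter: the aryl ring itself carries the effect, while the substituent on it has so far changed nothing beyond the scatter. Among the compounds with values here, no measured step covers a 3-methylphenyl. Compound 4 is therefore expected to stay close, with a 1.2-fold higher number from compound 3 to compound 4 (0.09 log units; within the scatter), and is estimated at 22 ug/mL, range 8 ug/mL to 65 ug/mL.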

Compound 4, half-maximal effective concentration: 116 ug/mL
Compound 4: the middle estimate sits 5.3-fold (0.72 log units) below what was measured; the measured number lies above the stated range.
By their numbers in this assay, from the lowest: compounds 3 and 1 (each within the scatter of the next); then compound 4. At a limit, above all of these: compound 2.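

On the aromatic carbon of the five-membered ring, the choice of aryl group now matters in this assay: a 6.6-fold higher number from compound 3 to compound 4 (0.82 log units; beyond the scatter), and a 5.4-fold higher number from compound 1 to compound 4 (0.73 log units; beyond the scatter), so an aryl ring alone does not fix the read-out. The 3-methylphenyl still keeps compound 4 clear of the methyl compound, an at least 2.5-fold lower number from compound 2 to compound 4 (0.41 log units; beyond the scatter), a bound only, as compound 2 stands at a limit of the assay: the limit of > 300 ug/mL in this assay, at which 1 of the 4 values shown sits.

Open, on these data alone, is whether a 4-methylphenyl would read like compound 3 or like compound 4. Also open, as far as these compounds go, is how a phenyl ring bearing an amine or a carboxylic acid would read.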